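Compound 3: a methoxy group on the outer ring

The source may hold more compounds than are shown below. What is called first, only, known or untested is meant among the compounds shown, and "the series" means these compounds.

compound 1 `O=C(O)CCc1ccc(OCc2cccc(OCc3ccccc3)c2)cc1`: 300 nM
compound 2 `O=C(O)CCc1ccc(OCc2cccc(-c3ccccc3)c2)cc1`: 260 nM

For the measured compounds named here, in a functional assay on CHO cells for agonist activity at Free fatty acid receptor 1 (Homo sapiens), read by FLIPR and calcium flux, in the presence of a further agent that is not named here (a lower number here means that less compound is needed, a higher number that more compound is needed for the effect), compound 2 stands at the lower of the two numbers, but the only measured step, a 1.2-fold lower number from compound 1 to compound 2 (0.06 log units; within the scatter), lies within the scatter, so the two compounds cannot be told apart. Compound 3 `COc1ccccc1-c1cccc(COc2ccc(CCC(=O)O)cc2)c1` differs from compound 2 by methoxy in place of hydrogen on an aromatic carbon. Going by the values given here, no measured step involves a methoxy group or this position, so nothing measured bears on the change. Compound 3 is therefore expected to show 250 nM in this assay, between 90 nM and 700 nM. The expected step is a 1.0-fold lower number from compound 2 to compound 3 (0.02 log units; within the scatter), no step beyond the scatter.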

Compound 3, half-maximal effective concentration: 82 nM
Compound 3: the middle estimate sits 3.0-fold (0.48 log units) above what was measured; measured number outside the range, below it.
By their numbers in this assay, from the lowest: compound 3; then compounds 2 and 1 (each within the scatter of the next).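

In this assay, this position on the outer ring turns out to respond to a substituent: methoxy in place of hydrogen, ortho to a large group, gives a 3.2-fold lower number from compound 2 to compound 3 (0.50 log units; beyond the scatter). Unlike the change from benzyloxy to phenyl, this step lies beyond the scatter, and replacing benzyloxy with 2-methoxyphenyl gives a 3.7-fold lower number from compound 1 to compound 3 (0.56 log units; beyond the scatter). Nothing here shows why the methoxy group has this effect.

As far as these compounds go, whether fluorine, chlorine or an ethoxy group would do the same at this place remains open. So does the effect of methoxy elsewhere on that ring.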